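Swapping the Dimethoxyphenyl Ring for Chloro-Nitrophenyl

The source may hold more compounds than are shown below. What is called first, only, known or untested is meant among the compounds shown, and "the series" means these compounds.

Of the compounds shown here, two have been measured so far. Compound 1 `COc1cc(C(=O)N/N=C/c2ccccc2C(F)(F)F)cc(OC)c1OC` and compound 2 `COc1cc(C2=NN(C(C)=O)C(c3cccc(OC)c3OC)O2)cc(OC)c1OC` were both tested in a functional assay on BGC-823 cells (Homo sapiens) for antiproliferative activity, read by MTT assay, tested at 1 uM; a lower number here means a weaker effect, a higher number a stronger effect of the compound at the concentration tested. Compound 1 gives 22.1% there, while compound 2 gives 3.8%, the lower of the two numbers, and the gap between them lies beyond the usual scatter. Compound 3 `COc1cc(C2=NN(C(C)=O)C(c3ccc(Cl)c([N+](=O)[O-])c3)O2)cc(OC)c1OC` has not been measured yet. It differs from compound 2 in a single place: 4-chloro-3-nitrophenyl in place of 2,3-dimethoxyphenyl on a saturated ring carbon. Among the measured compounds shown here, no measured pair isolates a change of this kind, so the direction cannot be read from the data. Compound 2 sits close to the floor of the read-out, so any fall would be small, while a rise of moderate size cannot be ruled out. The step from compound 2 to compound 3 in this assay is expected to be a number 5.2 percentage points higher from compound 2 to compound 3 (within the scatter), most likely within the scatter. Compound 3 is estimated to give 9% in this assay, with a likely range from 0% to 28%.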

Compound 3, a percentage reported as inhibition, at one concentration (the size of the read-out at that concentration, not a potency): -2.3%
Compound 3: middle estimate off by 11.3 percentage points, on the high side, and the stated range ends above it.
By their numbers in this assay, from the lowest: compounds 3 and 2 (each within the scatter of the next); then compound 1.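

In this assay, among the compounds shown here, placing 4-chloro-3-nitrophenyl in place of 2,3-dimethoxyphenyl on the saturated ring carbon gives a number 6.1 percentage points lower from compound 2 to compound 3 (within the scatter), and this is the first pair that isolates a change at this position. The two groups differ in their atoms and substituents but share the same counts of heavy atoms and hydrogen-bond acceptors, and this exchange leaves compound 3 indistinguishable from compound 2 in this read-out, with both close to its floor. No measurement available here bears on why the exchange makes no clear difference.

Going by these compounds, whether any group on this ring carbon can raise the read-out remains open, for example a phenyl ring carrying an amine or a carboxylic acid. Also open, on these data alone, is whether replacing the acetyl group on the ring nitrogen would matter more than this exchange did.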